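Butyl ether in place of aryl ether: one step followed

The source may report more compounds than this note shows. Statements on the series, on what has been measured and on what is new or still open speak of the compounds shown alone.

Of the compounds shown here, three built on a shared core have been tested in a functional assay on PC-3 cells (Homo sapiens) for inhibition, read by sulforhodamine B assay, with a stated time of 48 h, tested at 50 uM; a lower number here means less inhibition of growth, a higher number more inhibition of growth at the concentration tested. Compound 1 `COc1cc2c(cc1CC=C(C)C)C(=O)C[C@@H](c1ccc(Oc3ccc(F)cc3)cc1)O2` gives 19%, the lowest of the three numbers. The nearest is compound 2 `COc1ccc([C@@H]2C/C(=N/OCc3cn(-c4ccc(C(=O)c5ccccc5)cc4)nn3)c3cc(CC=C(C)C)c(OC)cc3O2)cc1`, which in this assay reaches 40%, a gap that lies beyond the usual scatter. Furthest away is compound 3 `COc1cc2c(cc1CCC(C)C)C(=O)C[C@@H](c1ccc(O)cc1)O2`, which in this assay gives 78%, again well beyond the scatter.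

The step to be followed leads from compound 1 to compound 4 `CCCCOc1ccc([C@@H]2CC(=O)c3cc(CC=C(C)C)c(OC)cc3O2)cc1`, whose result in this assay is not yet known. The change is butyl in place of 4-fluorophenyl on an oxygen on an aromatic ring. Among the compounds with values here, no pair of measured compounds differs in only this one place, so there is no measured step to lean on; the gap between compound 1 and compound 3 involves several changes at once and shows only that the shared core can carry strong inhibition.

For compound 4 a small rise is expected, a number 11 percentage points higher from compound 1 to compound 4 (beyond the scatter). Compound 1 in this assay sits at 19%. That number leaves more room upward than downward. The estimate for compound 4 is therefore 30%, with a range from 10% to 55%.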

Compound 4, percent growth inhibition at one concentration: 48%
Compound 4: middle estimate off by 18 percentage points, on the low side; low and high end bracket the measured number.
By their numbers in this assay, from the lowest: compound 1; then compounds 2 and 4 (each within the scatter of the next); then compound 3.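

Replacing the 4-fluorophenyl on the oxygen with butyl swaps an aromatic ring for an open chain, and in this assay this gives a number 29 percentage points higher from compound 1 to compound 4 (beyond the scatter). Within the data shown here, this is the first single-place comparison, and it shows that the group on this oxygen affects the result, which the earlier compounds could not show because they differ from one another in several places at once. It also shows that, on the core of compound 1, an aromatic ring is not needed at this position for growth inhibition at the tested concentration, although nothing measured here explains why the open chain gives the higher number.

A single step cannot separate the loss of the ring from the arrival of the chain, so a plain phenyl or a cyclohexyl on the same oxygen would be needed to tell these two apart. The compounds shown also leave open how the number changes with chain length, as with ethyl or hexyl, or with a butyl chain ending in an amine or a carboxylic acid.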